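This account rests on a few compounds, and the source may have more. Where it says the series, first, only, none or still open, it means among the compounds named here.

Compound 1 `CC1=C(C(=O)Nc2ccc(Br)cc2)C(c2ccc(Cl)cc2Cl)N=C(SCc2ccccc2Cl)N1`: 22.2%
Compound 2 `COc1ccc(C2N=C(SCc3ccccc3)NC(C)=C2C(=O)Nc2ccc(Br)cc2)cc1`: 10.3%

In a functional assay on the whole organism (artery, strain albino) with Rattus norvegicus as the target, with a stated time of 180 min, at a dose of 10 mg/kg by the oral route (a lower number here means less inhibition, a higher number more inhibition at the dose given (going by the name of the read-out)), compound 2 gives 10.3%, the lowest of the two numbers; compound 1 stands higher by a margin beyond the scatter, but the two differ in more than one place, so the values alone are all they show. Compound 3 `COc1ccc(C2N=C(SCc3ccccc3Cl)NC(C)=C2C(=O)Nc2ccc(Br)cc2)cc1` differs from compound 2 in one place: chloro in place of hydrogen on an aromatic carbon. Among the compounds with values here, no single-point step of this kind has been measured, so the expectation rests on the bare values. Compound 3 is expected to give 18%, within 5% to 35%, a small estimated rise of a number 7.7 percentage points higher from compound 2 to compound 3 (within the scatter) that may not exceed the scatter.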

Compound 3, a percentage reported as inhibition, in the whole organism at one dose (the size of the read-out at that dose, not a potency): 11.3%
The estimate for compound 3 lay 6.7 percentage points above the measured number, and the stated range covers the measured number.
By their numbers in this assay, from the lowest: compounds 2 and 3 (each within the scatter of the next); then compound 1.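

In this assay, the step for chloro in place of hydrogen, which turns benzyl into 2-chlorobenzyl, reads a number 1 percentage points higher from compound 2 to compound 3 (within the scatter), so at this position, with 4-methoxyphenyl on the saturated ring carbon, the chloro makes no difference that can be told from the scatter. With 2-chlorobenzyl held the same, 4-methoxyphenyl in place of 2,4-dichlorophenyl gives a number 10.9 percentage points lower from compound 1 to compound 3 (beyond the scatter), so the saturated ring carbon is the one place here where a single change exceeds the scatter. No measurement explains either step.

Going by these compounds, whether an amine or a longer chain at the benzyl position would separate from these values remains open. So does whether chloro would matter alongside 2,4-dichlorophenyl.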